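Series notes: open-chain amine in place of piperazine, compound 3

The source may hold more compounds than are shown below. What is called first, only, known or untested is meant among the compounds shown, and "the series" means these compounds.

Among the compounds with values here, compound 2 `CCCCCCCCCCc1ccc(-c2noc(CN3CCNCC3)n2)cc1` gives 19% in an assay on HeLa cells for inhibition of sphingosine-1-phosphate transporter SPNS2 (Mus musculus), read by LC-MS, tested at 2 uM (a lower number here means less inhibition, a higher number more inhibition at the concentration tested (going by the name of the read-out)), the lowest of the two numbers so far; compound 1 `CCCCCCCCCCc1ccc(-c2noc(C3CNC3)n2)cc1` gives 65%. Within the data shown here, the single measured step, a number 46 percentage points lower from compound 1 to compound 2 (beyond the scatter), is the only one that bears on the present change, and only loosely, since it alters the same position with a different group. Compound 3 `CCCCCCCCCCc1ccc(-c2noc(C(Cl)CCN)n2)cc1` differs from compound 2 by a group of 5 heavy atoms (3 carbon, 1 nitrogen, 1 chlorine; no ring) in place of a group of 7 heavy atoms (5 carbon, 2 nitrogen; one six-membered non-aromatic ring with 2 hetero atoms), on an aromatic carbon. Among the measured compounds shown here, no measured step covers a group without a ring at this position, so the direction is open. Compound 3 is expected to give 40% in this assay, within 10% to 75%. The estimated step is a number 21 percentage points higher from compound 2 to compound 3 (beyond the scatter).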

Compound 3, a percentage reported as inhibition, at one concentration (the size of the read-out at that concentration, not a potency): 5%
The estimate for compound 3 lay 35 percentage points above the measured number; the measured number lies below the stated range.
By their numbers in this assay, from the lowest: compound 3; then compound 2; then compound 1.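

In this assay a chlorine-bearing open chain without a ring does not restore inhibition at this position: the change gives a number 14 percentage points lower from compound 2 to compound 3 (beyond the scatter) and, set against the azetidin-3-yl group, a number 60 percentage points lower from compound 1 to compound 3 (beyond the scatter). Of the three groups on this aromatic carbon, the azetidin-3-yl group of compound 1 alone stands well clear of the other two, and compound 3 gives the lowest number. Nothing available accounts for these steps. The compounds shown do not separate the chlorine from the loss of the ring. A plain 3-aminopropyl chain without chlorine, or a pyrrolidin-3-yl ring, at this position would bear on that question.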